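The compounds below may be only part of what the source reports. "The series", "measured", "known", "first", "only" and "open" are said of these compounds alone.

Measured so far:
compound 1 `O=C(NNC(=S)Nc1csc(-c2ccccc2)c1)c1ccc(O)cc1` gives 80000 nM
compound 2 `Cc1ccc(-c2cc(NC(=S)NNC(=O)c3ccc(O)cc3)cs2)cc1` gives 49000 nM
compound 3 `Oc1ccc(-c2nnc(Nc3csc(-c4ccccc4)c3)s2)cc1` gives 26000 nM

All three were tested in a functional assay on Hs 683 cells (Homo sapiens) for inhibition, read by colorimetric assay and MTT assay, with a stated time of 72 h; a lower number here means a stronger inhibitor, a higher number a weaker inhibitor. Compound 1 and compound 2 share one core and differ only by methyl in place of hydrogen on an aromatic carbon; this change made a step of a 1.6-fold lower number from compound 1 to compound 2 (0.21 log units; within the scatter). Compound 3 has a different core, and the difference between the two cores is not broken down here. Compound 4 `Cc1ccc(-c2cc(Nc3nnc(-c4ccc(O)cc4)s3)cs2)cc1` is not yet measured; it relates to compound 3 exactly as compound 2 relates to compound 1, differing by methyl in place of hydrogen on an aromatic carbon. The surroundings of the place are the same in both pairs, so this is the same change. Among the compounds with values here, from compound 3 to compound 4 a step of about a 1.4-fold lower number from compound 3 to compound 4 (0.16 log units; within the scatter) is expected, resting on the single earlier example a 1.6-fold lower number from compound 1 to compound 2 (0.21 log units; within the scatter), which itself lay within the scatter. Compound 4 is therefore estimated at 18000 nM, with a likely range from 8000 nM to 40000 nM.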

Compound 4, half-maximal inhibitory concentration: 17000 nM
For compound 4 the middle estimate is 1.1-fold (0.02 log units) above the measured one, within the range that was stated.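

In this assay methyl in place of hydrogen gave a 1.5-fold lower number from compound 3 to compound 4 (0.18 log units; within the scatter) and this step matches the earlier one on the other core: the same change on two cores in this assay, a 1.6-fold lower number (0.21 log units; within the scatter) from compound 1 to compound 2 and a 1.5-fold lower number (0.18 log units; within the scatter) from compound 3 to compound 4, 1.1-fold (0.03 log units) apart, within the scatter of two such steps

So phenyl to 4-methylphenyl behaved alike on the two cores, and the step read on one core was a fair guide to the other. Each step lies within the scatter, however, so the pair does not show that the methyl changes the number at all, and two cores are too few for a general rule.

The compounds shown leave open what other groups at this place, such as a methoxy group, a chlorine atom or an amine, would do. They also leave open whether a larger step would carry across both cores in the same way.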